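Second trifluoromethyl on the hydrazone aryl ring: A549 notes

This account rests on a few compounds, and the source may have more. Where it says the series, first, only, none or still open, it means among the compounds named here.

Measured in a functional assay on A549 cells (Homo sapiens) for inhibition, read by MTT assay, with a stated time of 72 h; on this read-out higher numbers stand for weaker inhibition and lower numbers for stronger inhibition:
compound 1 `CN(C(=O)NC(=O)c1ccc(Cl)cc1Cl)c1nc(C(F)(F)F)c(C(=O)N/N=C/c2cccc(C(F)(F)F)c2)s1`: 10.6 ug/mL.
compound 2 `CN(C(=O)NC(=O)c1ccc(Cl)cc1Cl)c1nc(C(F)(F)F)c(C(=O)N/N=C/c2cc(C(F)(F)F)cc(C(F)(F)F)c2)s1`: a limit of the assay, > 100 ug/mL.
compound 3 `Cc1nc(N(C)C(=O)NC(=O)c2c(F)cccc2F)sc1C(=O)N/N=C/c1cccc(C(F)(F)F)c1`: 30.3 ug/mL.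

Of the two numbers, compound 3 stands highest; compound 1 is the nearer, its number lower than that of compound 3 by a gap beyond the scatter. The difference between the core of compound 1 and the core of compound 3 is not broken down here.

Among the measured compounds shown here, the one counted change is trifluoromethyl in place of hydrogen on an aromatic carbon, which gave an at least 9.4-fold higher number from compound 1 to compound 2 (0.97 log units; beyond the scatter); compound 2 sits at the limit of > 100 ug/mL in this assay, at which 1 of the 3 values shown sits, so the size of that step is known only as a lower bound.

Compound 4 `Cc1nc(N(C)C(=O)NC(=O)c2c(F)cccc2F)sc1C(=O)N/N=C/c1cc(C(F)(F)F)cc(C(F)(F)F)c1` carries the same change on the core of compound 3: trifluoromethyl in place of hydrogen on an aromatic carbon. The step from compound 3 to compound 4 is expected to be a 4.0-fold higher number from compound 3 to compound 4 (0.60 log units; beyond the scatter), resting on compound 1 and compound 2 with an at least 9.4-fold higher number from compound 1 to compound 2 (0.97 log units; beyond the scatter). Since compound 3 already starts at 30.3 ug/mL, compound 4 is expected near 120 ug/mL, between 40 ug/mL and 300 ug/mL. It is also possible that for compound 4 only a limit of the assay will be reported.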

Compound 4, half-maximal inhibitory concentration: 13 ug/mL
Compound 4: middle estimate off by 9.2-fold (0.97 log units), on the high side; measured number outside the range, below it.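

In this assay, the added trifluoromethyl does not carry over from one core to the other, as a 2.3-fold lower number from compound 3 to compound 4 (0.37 log units; beyond the scatter) runs opposite to the step seen on the core of compound 1: the same change on two cores in this assay, an at least 9.4-fold higher number (0.97 log units; beyond the scatter) from compound 1 to compound 2 and a 2.3-fold lower number (0.37 log units; beyond the scatter) from compound 3 to compound 4, at least 21-fold (1.34 log units) apart, beyond the scatter of two such steps. Compound 2 stands at a limit of the assay, > 100 ug/mL: the limit of > 100 ug/mL in this assay, at which 1 of the 4 values shown sits. This pair of steps shows that the result on one core is a poor guide to the result on the other in this series, but it does not show which feature of the cores is responsible, since the core of compound 1 and the core of compound 3 differ in more than one place, and one pair per core sets no rule for any further core.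

Which part of the core decides the direction of the step remains open. Also open, as far as these compounds go, is how a nitrile or an amine in place of the hydrogen on that aromatic carbon would read on each of the two cores.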